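Amide variation on the pyrazine series: compound 3 to compound 4

The compounds below may be only part of what the source reports. "The series", "measured", "known", "first", "only" and "open" are said of these compounds alone.

Compound 3 `CC(=O)N1CCC(NC(=O)c2ccncc2Nc2cc(-c3ccc4ccn(C)c4c3)c3nccnc3c2)CC1` is the reference point for this step. In an assay for inhibition of 6-phosphofructo-2-kinase/fructose-2,6-bisphosphatase 3 (Homo sapiens), read by ADP-Glo, with a stated time of 2 h (a lower number here means a stronger inhibitor, a higher number a weaker inhibitor), compound 3 gives 18 nM, the lowest of the three numbers recorded. Compound 1 `CNS(=O)(=O)c1ccccc1Nc1cc(-c2ccc3ccn(C)c3c2)c2nccnc2c1` gives 104 nM in this assay, and compound 2 `Cn1ccc2ccc(-c3cc(Nc4ccccc4S(=O)(=O)Nc4cncnc4)cc4nccnc34)cc21` gives 1690 nM; compound 3 stands clear of both, beyond the scatter in each case.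

Compound 4 `CN1CCC(N(C)C(=O)c2ccncc2Nc2cc(-c3ccc4ccn(C)c4c3)c3nccnc3c2)C1` keeps the shared core and the carboxamide but alters the amide side: methyl(1-methylpyrrolidin-3-yl)amino in place of (1-acetylpiperidin-4-yl)amino on a carbonyl carbon. Among the measured compounds shown here, the only measured step in the set, a 16-fold higher number from compound 1 to compound 2 (1.21 log units; beyond the scatter), concerns a sulfonamide nitrogen elsewhere on the core and does not speak to a change on the amide. For the measured compounds named here, no measured pair shows what the loss of the amide hydrogen or the swap of ring size does here.

Going by the values given here, with no direct precedent, a modest weakening is expected for compound 4 in this assay, as a 2.2-fold higher number from compound 3 to compound 4 (0.35 log units; beyond the scatter), on the ground that compound 3 at 18 nM sits at the strong end of the series and a reshaped amide substituent more often costs than gains. The estimate for compound 4 in this assay is 40 nM, with a range from 12 nM to 150 nM.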

Compound 4, half-maximal inhibitory concentration: 176 nM
Compound 4: the middle estimate sits 4.4-fold (0.64 log units) below what was measured; measured number outside the range, above it.
By their numbers in this assay, from the lowest: compound 3; then compounds 1 and 4 (each within the scatter of the next); then compound 2.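

In this assay, among the compounds shown here, the amide side of the shared core proves sensitive to its substituent, with a 9.8-fold higher number from compound 3 to compound 4 (0.99 log units; beyond the scatter) on replacing (1-acetylpiperidin-4-yl)amino with methyl(1-methylpyrrolidin-3-yl)amino on a carbonyl carbon; this is the first measured step at this place, as the earlier step concerned a sulfonamide nitrogen. For the compounds shown here, the change is compound, since the six-membered ring gives way to a five-membered one, the acetyl group is lost, and the hydrogen-bond donor of the leaving group has no counterpart in the entering group, so this single step cannot assign the shift to any one of these features. No available evidence bears on the reason for this shift.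

The compounds shown leave open which of these features carries the step, and groups that change one feature at a time, such as (1-methylpyrrolidin-3-yl)amino, which keeps the amide hydrogen, or methyl(1-acetylpiperidin-4-yl)amino, which keeps the acetylpiperidine, would separate them. Also open, going by these compounds, is how simpler groups on the same carbonyl carbon, such as a plain dimethylamino or morpholine, would read in this assay.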